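A few compounds are considered here, and "the series" means these few. Any claim that something is new, unique, unknown or untested is made for them only; others in the source may bear on it.

Measured compounds:
compound 1 `CN(C(=O)N1CC[C@H](n2cnc3cc(-c4ccc(Cl)cc4)sc3c2=O)C1)[C@H]1CCN(CC2CCCCC2)C1`, giving 50 nM in an assay on isolated protein for binding affinity to melanin-concentrating hormone receptor 1 (Homo sapiens); a lower number here means a stronger inhibitor, a higher number a weaker inhibitor;
compound 2 `Cc1ccc(-c2cc3ncn([C@H]4CCN(C(=O)N(C)[C@H]5CCN(C)C5)C4)c(=O)c3s2)cc1`, giving 15 nM in this assay;
compound 3 `Cc1ccc(-c2cc3ncn([C@H]4CCN(C(=O)N(C)[C@H]5CCN(C6CCOCC6)C5)C4)c(=O)c3s2)cc1`, giving 14 nM in this assay.

Compound 3 has the lowest number of the three, but its gap to compound 2 is within the scatter, so the two cannot be told apart; only compound 1 stands clearly apart, with a higher number. Among the compounds with values here, the one single-point step in this set, a 1.1-fold lower number from compound 2 to compound 3 (0.03 log units; within the scatter), changed the group on the amine nitrogen in a ring and left the number essentially unchanged.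

Compound 4 `CN(C(=O)N1CC[C@H](n2cnc3cc(-c4ccc(C(F)(F)F)cc4)sc3c2=O)C1)[C@H]1CCN(C2CCOCC2)C1` differs from compound 3 at a different place: trifluoromethyl in place of methyl on an aromatic carbon. Within the data shown here, no measured step alters this group alone. Compound 1 carries a different group on that aromatic ring, but it also differs from compound 3 at the amine nitrogen, so its higher number cannot be assigned to either change. The step from compound 3 to compound 4 is therefore uncertain, and the expectation rests only on the observation that the shared core has so far tolerated changes at its periphery. Compound 4 is expected to come out at 20 nM, in the range 6 nM to 70 nM, meaning an estimated step of a 1.4-fold higher number from compound 3 to compound 4 (0.15 log units; within the scatter), not beyond the scatter.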

Compound 4, inhibition constant: 19 nM
For compound 4 the middle estimate is 1.1-fold (0.02 log units) above the measured one, and the stated range covers the measured number.
By their numbers in this assay, from the lowest: compounds 3, 2 and 4 (each within the scatter of the next); then compound 1.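

In this assay, the change from 4-methylphenyl to 4-(trifluoromethyl)phenyl gives a 1.4-fold higher number from compound 3 to compound 4 (0.13 log units; within the scatter), so the two compounds cannot be told apart. This is the first step shown that alters this position alone, on an aromatic carbon para to a large group, and it indicates that, at least in this pair, going from methyl with 1 heavy atom to trifluoromethyl with 4 heavy atoms leaves binding affinity essentially unchanged. No measurement is available that would explain this outcome.

The compounds shown leave open whether a much more different group on that same aromatic carbon, such as an amine, a carboxylic acid or a methoxy group, would also leave the number essentially unchanged, since methyl and trifluoromethyl are the only two groups there that can be compared directly. As far as these compounds go, it also remains open whether the same change would give a similar result with a different group on the amine nitrogen in the ring, such as the methyl of compound 2, as this single pair carries only oxan-4-yl there.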